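The source may hold more compounds than are shown below. What is called first, only, known or untested is meant among the compounds shown, and "the series" means these compounds.

Measured compounds in a physicochemical assay for solubility, in phosphate buffer, measured as kinetic solubility, with a stated time of 1 h, at pH 7.4; a lower number here means a less soluble compound, a higher number a more soluble compound:
compound 1 `COc1ccc2nc(C)cc(OCC(=O)Nc3cc(C)c(F)c(C)c3)c2c1`, 31500 nM
compound 2 `COc1ccc2nc(C)cc(OCC(=O)Nc3ccc(Cl)c(OC)c3)c2c1`, 13000 nM
compound 3 `COc1ccc2nc(C)cc(OCC(=O)Nc3ccccn3)c2c1`, 29000 nM

All three share one core and differ only in the group on the amide-type nitrogen. Compound 3 stands second highest of the three numbers in this assay, with compound 1 nearest and compound 2 furthest. The two measured steps that end at compound 3 are a 1.1-fold lower number from compound 1 to compound 3 (0.04 log units; within the scatter) and a 2.2-fold higher number from compound 2 to compound 3 (0.35 log units; beyond the scatter); the first lies within the scatter, the second is a modest step beyond it. Between the two aryl groups themselves the step is a 2.4-fold lower number from compound 1 to compound 2 (0.38 log units; beyond the scatter).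

Compound 4 `COc1ccc2nc(C)cc(OCC(=O)NNC(=O)c3ccncc3)c2c1` has not been measured in this assay. The change from compound 3 is ((pyridin-4-yl)carbonyl)amino in place of pyridin-2-yl on an amide-type nitrogen. Among the measured compounds shown here, none of the measured steps covers a change of this kind: each of them swaps one ring for another ring directly on the amide-type nitrogen, whereas here the entering group brings a hydrogen-bond donor and two acceptors and is larger by the count given. The measured steps therefore only set the scale of what ring swaps on this nitrogen have done, which was at most modest. For compound 4 a step of a 1.4-fold higher number from compound 3 to compound 4 (0.14 log units; within the scatter) is expected, small and toward a higher number, but with a wide range. The estimate for compound 4 in this assay is 40000 nM, between 15000 nM and 100000 nM.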

Compound 4, solubility: >= 375000 nM
Compound 4: only a limit was reported; the forecaster's own chance of this, stated with the estimate: 10%; at least 9.3-fold (0.97 log units) between middle value and limit.
By their numbers in this assay, from the lowest: compound 2; then compounds 3 and 1 (each within the scatter of the next). At a limit, above all of these: compound 4.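

In this assay compound 4 sits at a limit of the assay and not at a number: the limit of >= 375000 nM in this assay, at which 1 of the 4 values shown sits.

Among the compounds shown here, with ((pyridin-4-yl)carbonyl)amino on the amide-type nitrogen, the series shows an at least 12-fold higher number from compound 3 to compound 4 (1.11 log units; beyond the scatter), then an at least 11-fold higher number from compound 1 to compound 4 (1.07 log units; beyond the scatter), and an at least 28-fold higher number from compound 2 to compound 4 (1.46 log units; beyond the scatter), all large, whereas the largest ring-for-ring step among the earlier compounds was a 2.4-fold lower number from compound 1 to compound 2 (0.38 log units; beyond the scatter). This position can therefore carry a far larger change in this read-out than the earlier ring swaps showed, and a six-membered aromatic ring with one hetero atom is present in both compound 3 and compound 4, so having such a ring does not by itself set compound 4 apart.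

For the compounds shown here, the true number for compound 4 remains open, so the full size of these steps is unknown, and the single change does not separate the carbonyl and the added nitrogen from the shift of the pyridine attachment to pyridin-4-yl. Benzoylamino or acetylamino on the same amide-type nitrogen would be needed to show whether the link alone gives a step of this size.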